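This account rests on a few compounds, and the source may have more. Where it says the series, first, only, none or still open, it means among the compounds named here.

In a functional assay on PANC-1 cells (Homo sapiens), read by microscopy, crystal violet staining and transwell migration, with a stated time of 18 h, in the presence of a further agent that is not named here (a lower number here means a stronger inhibitor, a higher number a weaker inhibitor), two amides on a shared core have been measured so far. Compound 1 `COc1ccc(-c2nc(C)nn2-c2cccc(C(=O)NCCCc3ccc(Cl)cc3)c2)cc1` reports > 20000 nM, which is a limit of the assay and not a number. Among the measured compounds shown here, compound 2 `COc1ccc(-c2nc(C)nn2-c2cccc(C(=O)NCCCOc3ccccc3)c2)cc1` gives 3120 nM, the only actual number available. For the measured compounds named here, the one measured step is an at least 6.4-fold lower number from compound 1 to compound 2 (0.80 log units; beyond the scatter), with phenoxy in place of 4-chlorophenyl on a saturated chain carbon. Compound 3 `COc1ccc(-c2nc(C)nn2-c2cccc(C(=O)NCCOCc3ccccc3)c2)cc1` has the same atoms as compound 2, joined differently: benzyloxy in place of phenoxymethyl on a saturated chain carbon, two bonds along the chain from an amide-type nitrogen. Going by the values given here, the measured step touches the same end of the chain but is a different change, so it shows only that a change there can be large. A modest rise in this assay is therefore expected, though a step within the scatter would be no surprise. The estimated step is a 1.6-fold higher number from compound 2 to compound 3 (0.20 log units; within the scatter). For compound 3 the expected value is 5000 nM, with an estimated range of 1500 nM to 17000 nM.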

Compound 3, half-maximal inhibitory concentration: 9340 nM
The estimate for compound 3 lay 1.9-fold (0.27 log units) below the measured number; the range from low to high includes it.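

Benzyloxy in place of phenoxymethyl, on a saturated chain carbon two bonds along the chain from an amide-type nitrogen, keeps the same atoms yet gives a 3.0-fold higher number from compound 2 to compound 3 (0.48 log units; beyond the scatter) in this assay, so how these atoms are joined matters here, not only which atoms are present. Benzyloxy in place of 4-chlorobenzyl at that same place gives an at least 2.1-fold lower number from compound 1 to compound 3 (0.33 log units; beyond the scatter), which means that both oxygen-bearing side chains read as stronger than the chlorinated one. The size of that step stays open-ended, since compound 1 carries a limit and not a number: the limit of > 20000 nM in this assay, at which 1 of the 3 values shown sits.

The compounds shown leave open whether the chlorine or the missing chain oxygen separates compound 1 from the others, which a 4-chlorophenoxy group would address. As far as these compounds go, how an amine in place of the chain oxygen, or a longer chain, would read also remains open.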